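Lengthening and trimming the acyl chain: notes on the series

This account rests on a few compounds, and the source may have more. Where it says the series, first, only, none or still open, it means among the compounds named here.

Measured in a functional assay on HeLa cells (Homo sapiens) for cytotoxicity, read by MTT assay, with a stated time of 24 h; on this read-out higher numbers stand for weaker inhibition and lower numbers for stronger inhibition:
- compound 1 `CCCCCCCCCCCCCCCCCC(=O)Nc1nnc(S[C@@H]2O[C@H](CO)[C@H](O)[C@H](O)[C@H]2O)s1`: 11200 nM
- compound 2 `CCCCCCCCCCCCCC(=O)Nc1nnc(S[C@@H]2O[C@H](CO)[C@H](O)[C@H](O)[C@H]2O)s1`: 31000 nM

Compound 2 holds the higher of the two numbers, with compound 1 as its nearest neighbour. Compound 3 `C=CCCCCCCCCC(=O)Nc1nnc(S[C@@H]2O[C@H](CO)[C@H](O)[C@H](O)[C@H]2O)s1` differs from compound 2 by vinyl in place of pentyl on a saturated chain carbon, eight bonds along the chain from a carbonyl carbon, with vinyl in place of pentyl on a saturated chain carbon, eight bonds along the chain from a carbonyl carbon. Going by the values given here, one measured step bears on this: a 2.8-fold higher number from compound 1 to compound 2 (0.44 log units; beyond the scatter), with hydrogen in place of butyl further along the chain. Among the compounds with values here, no measured step involves vinyl. A similarly modest move towards a higher number is therefore expected in this assay. The expected change is a 1.9-fold higher number from compound 2 to compound 3 (0.29 log units; within the scatter). For compound 3 the estimate is 60000 nM, with a range of 28000 nM to 130000 nM.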

Compound 3, half-maximal inhibitory concentration: 58300 nM
Estimate against measurement, compound 3: 1.0-fold (0.01 log units) above; measured number inside the range.
By their numbers in this assay, from the lowest: compound 1; then compounds 2 and 3 (each within the scatter of the next).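

In this assay, vinyl in place of pentyl on a saturated chain carbon, eight bonds along the chain from a carbonyl carbon, gives a 1.9-fold higher number from compound 2 to compound 3 (0.27 log units; within the scatter) and so does not separate compound 3 from compound 2. Vinyl in place of nonyl at that place gives a 5.2-fold higher number from compound 1 to compound 3 (0.72 log units; beyond the scatter) and does separate compound 3 from compound 1. No measurement shown accounts for either step.

The compounds shown leave the double bond and the chain length unseparated, since both differ in each step. On these data alone, a fully saturated chain matching compound 3 in length, or an amine or a carboxylic acid at this place, remains open.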